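This account rests on a few compounds, and the source may have more. Where it says the series, first, only, none or still open, it means among the compounds named here.

Compound 1 `CN1C/C(=C\c2cccc([N+](=O)[O-])c2)C(=O)/C(=C/c2ccccc2F)C1`: 1080 nM
Compound 2 `CN1C/C(=C\c2ccc(C#N)cc2)C(=O)/C(=C/c2ccccc2F)C1`: 590 nM
Compound 3 `CN1C/C(=C\c2ccc(F)cc2)C(=O)/C(=C/c2cccc([N+](=O)[O-])c2)C1`: 9340 nM

In a functional assay on HepG2 cells (Homo sapiens) for cytotoxicity, read by MTT assay, with a stated time of 24 h (a higher number here means a weaker inhibitor, a lower number a stronger inhibitor), compound 1 gives 1080 nM and compound 3 gives 9340 nM. The two differ in one place, (4-fluorophenyl in place of 2-fluorophenyl on a double-bonded chain carbon bound to a double-bonded ring carbon), and that change made the step of an 8.6-fold higher number from compound 1 to compound 3 (0.94 log units; beyond the scatter). Compound 2 gives 590 nM in this assay; its core differs from that of compound 1, and the difference is not broken down here. This number and that of compound 1 lie within the scatter of each other, while compound 3 gives a higher number than both.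

Compound 4 `CN1C/C(=C\c2ccc(F)cc2)C(=O)/C(=C/c2ccc(C#N)cc2)C1` has not been measured. It differs from compound 2 by 4-fluorophenyl in place of 2-fluorophenyl on a double-bonded chain carbon bound to a double-bonded ring carbon, the same change as from compound 1 to compound 3, at the same place. For compound 4 a step of similar size is expected, an 8.5-fold higher number from compound 2 to compound 4 (0.93 log units; beyond the scatter), because the earlier change gave an 8.6-fold higher number from compound 1 to compound 3 (0.94 log units; beyond the scatter). Compound 4 is therefore estimated at 5000 nM in this assay, between 1500 nM and 16000 nM.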

Compound 4, half-maximal inhibitory concentration: 6140 nM
Beside the measured number, compound 4's estimate is 1.2-fold (0.09 log units) below it, and the stated range covers the measured number.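

In this assay, 4-fluorophenyl in place of 2-fluorophenyl on a double-bonded chain carbon bound to a double-bonded ring carbon gave a 10-fold higher number from compound 2 to compound 4 (1.02 log units; beyond the scatter). The change carried over from one core to the other with much the same size: the same change on two cores in this assay, an 8.6-fold higher number (0.94 log units; beyond the scatter) from compound 1 to compound 3 and a 10-fold higher number (1.02 log units; beyond the scatter) from compound 2 to compound 4, 1.2-fold (0.08 log units) apart, within the scatter of two such steps. Among the compounds shown here, this rests on only two pairs in a single assay, so it shows that the step held on these two cores, but it does not show that it would hold on other cores, nor why it has this size.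

The compounds shown leave open how the same change would behave with an amine or a carboxylic acid on the other phenyl ring. They also leave open whether 4-chlorophenyl would follow 4-fluorophenyl.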